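This account rests on a few compounds, and the source may have more. Where it says the series, first, only, none or still open, it means among the compounds named here.

Compound 1 `CC(=O)N[C@@H](CSC(=O)Nc1ccccc1F)C(=O)O`: > 200000 nM
Compound 2 `COc1ccc(NC(=O)SC[C@H](NC(C)=O)C(=O)O)cc1`: 75200 nM

These two compounds were tested in a functional assay on UACC-62 cells (Homo sapiens) for cytotoxicity, read by MTT assay, with a stated time of 6 days; on this read-out lower numbers stand for stronger inhibition and higher numbers for weaker inhibition. Compound 1 gives > 200000 nM, which is a limit of the assay and not a number. So its true position is unknown, and any step away from it can only be judged roughly. Compound 2 gives 75200 nM, a true measured number.

Compound 3 `CSc1ccccc1NC(=O)SC[C@H](NC(C)=O)C(=O)O` is made from compound 1 by one change: methylsulfanyl in place of fluoro on an aromatic carbon, ortho to a large group (methylsulfanyl in place of fluoro on an aromatic carbon). The rest of the molecule stays the same. Among the compounds with values here, no measured pair in this small set shows the effect of a single change like this one, so the expectation has little to rest on.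

Compound 2 reaches 75200 nM, so a measurable number in the same broad region also seems possible for compound 3. Another limit reading for compound 3 could not be ruled out. A modest move towards stronger inhibition is expected, estimated as an at least 2.0-fold lower number from compound 1 to compound 3 (0.30 log units; that floor lies within the scatter). For compound 3 the estimated value is 100000 nM, with an expected range from 35000 nM to 250000 nM.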

Compound 3, half-maximal inhibitory concentration: > 200000 nM
Compound 3 gave a limit, no number; the forecaster's own chance of this, stated with the estimate: 35%; middle value at least 2.0-fold (0.30 log units) away from the limit.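

In this assay compound 3 gives > 200000 nM and this is a limit of the assay, not a number. Compound 1 also stands at a limit, so no step can be read between compound 1 and compound 3, because neither has a true number: the limit of > 200000 nM in this assay, at which 2 of the 3 values shown sit. The compounds shown leave open whether methylsulfanyl in place of fluoro changes inhibition at all, and in which direction.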